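The compounds below may be only part of what the source reports. "The series", "measured", "known", "first", "only" and "open" are said of these compounds alone.

Working notes on the series in an ADME assay on HepG2 2.2.15 cells (Homo sapiens) for cytotoxicity; on this read-out higher numbers stand for lower toxicity in this test and lower numbers for higher toxicity in this test.

Among the measured compounds shown here, compound 3 `CCCCCCCC(=O)OCCc1c(-c2ccccc2Cl)c2cc(Cl)ccc2[nH]c1=O` stands highest of the three numbers known so far: in this assay compound 3 gives 78000 nM. Its nearest neighbour is compound 2 `O=c1c(CCO)c(-c2ccccc2Cl)c2cc(Cl)ccc2n1-c1ccccc1`, which in this assay gives 26000 nM, and the furthest is compound 1 `C=CCn1c(=O)c(CCO)c(-c2ccccc2Cl)c2cc(Cl)ccc21`, which in this assay gives 23000 nM; both of those gaps to compound 3 lie beyond the scatter.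

For the measured compounds named here, the one measured single-point step, a 1.1-fold higher number from compound 1 to compound 2 (0.05 log units; within the scatter), concerns a substituent on an aromatic nitrogen and does not touch the ester that carries the change now under study.

Compound 4 `O=C(OCCc1c(-c2ccccc2Cl)c2cc(Cl)ccc2[nH]c1=O)c1ccco1` differs from compound 3 in one place: furan-2-yl in place of heptyl on a carbonyl carbon. Going by the values given here, no measured step in this set alters the group on that carbonyl carbon, so nothing here speaks for a shift in either direction. The expectation is therefore a number for compound 4 close to compound 3, a step of a 1.3-fold lower number from compound 3 to compound 4 (0.11 log units; within the scatter) with a wide allowance. Compound 4 is estimated at 60000 nM, within 25000 nM to 140000 nM.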

Compound 4, half-maximal cytotoxic concentration: 98000 nM
Estimate against measurement, compound 4: 1.6-fold (0.21 log units) below, and the stated range covers the measured number.
By their numbers in this assay, from the lowest: compounds 1 and 2 (each within the scatter of the next); then compounds 3 and 4 (each within the scatter of the next).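

In this assay the group on the carbonyl carbon of the ester now has a measured step of its own (a 1.3-fold higher number from compound 3 to compound 4 (0.10 log units; within the scatter)), and it lies within the scatter. Furan-2-yl in place of heptyl swaps an open chain for a five-membered aromatic ring with one hydrogen-bond acceptor, and at this position that exchange leaves the read-out unresolved from that of the heptyl ester. No measurement on hand offers an explanation for this step.

On these data alone, whether a methyl group, a longer chain, an amine or a carboxylic acid on that carbonyl carbon would also stay within the scatter remains open. The ester's own contribution also stays unseparated, since the free alcohol compounds shown carry allyl or phenyl on the aromatic nitrogen, and the free alcohol with the hydrogen on that nitrogen would be needed for a single-place comparison.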